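Cyclopropyl for phenyl on the amide carbonyl

The source may hold more compounds than are shown below. What is called first, only, known or untested is meant among the compounds shown, and "the series" means these compounds.

Compound 1 `O=C(c1ccccc1)N1CCC(NCCSC(c2ccc(F)cc2)c2ccc(F)cc2)CC1`: 4.51 nM
Compound 2 `O=C(c1ccc(F)cc1)N1CCC(NCC[S+]([O-])C(c2ccc(F)cc2)c2ccc(F)cc2)CC1`: 77.2 nM

Within the data shown here, in an assay on membranes from striatum (strain Sprague-Dawley) for displacement of a labelled ligand from sodium-dependent dopamine transporter (Rattus norvegicus), read by scintillation counting, with a stated time of 120 min (on this read-out lower numbers stand for stronger inhibition and higher numbers for weaker inhibition), compound 1 gives 4.51 nM, the lower of the two numbers; compound 2 gives 77.2 nM, a higher number by a gap beyond the scatter, though the two differ in more than one place and give no single step. Compound 3 `O=C(C1CC1)N1CCC(NCCSC(c2ccc(F)cc2)c2ccc(F)cc2)CC1` keeps the shared core of compound 1 and differs by cyclopropyl in place of phenyl on a carbonyl carbon. Among the measured compounds shown here, no measured step of this kind exists. A modest weakening is expected, with a 2.7-fold higher number from compound 1 to compound 3 (0.43 log units; beyond the scatter) estimated near the edge of the scatter. Compound 3 is estimated in this assay at 12 nM, within 4 nM to 40 nM.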

Compound 3, inhibition constant: 178 nM
The estimate for compound 3 lay 15-fold (1.17 log units) below the measured number, outside the stated range (above it).
By their numbers in this assay, from the lowest: compound 1; then compound 2; then compound 3.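

In this assay, among these compounds, cyclopropyl in place of phenyl on a carbonyl carbon gives a 39-fold higher number from compound 1 to compound 3 (1.60 log units; beyond the scatter) as the first single-place step. With the rest of compound 1 held fixed, this position is clearly sensitive to the change, and the smaller cyclopropyl ring does not stand in for phenyl here. Nothing available explains the size of this step.

Still open, on these data alone, is whether cyclohexyl, pyridyl or benzyl on this carbonyl carbon would stay close to compound 1 or fall towards compound 3. An amine-bearing phenyl ring at the same place is equally unresolved.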